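The source may hold more compounds than are shown below. What is called first, only, known or untested is meant among the compounds shown, and "the series" means these compounds.

Measured compounds:
compound 1, `N=C(N)c1ccc(-c2ccc(-c3cc(Cl)cc(Cl)c3)s2)cc1`, 2050 nM
compound 2, `N=C(N)c1ccc(-c2ccc(-c3ccc(Cl)cc3)s2)cc1F`, 726 nM

Of the compounds shown here, two have been measured in a functional assay on Hs-578T cells (Homo sapiens) for inhibition, read by sulforhodamine B assay, with a stated time of 48 h; a lower number here means a stronger inhibitor of growth, a higher number a weaker inhibitor of growth. Compound 1 `N=C(N)c1ccc(-c2ccc(-c3cc(Cl)cc(Cl)c3)s2)cc1` gives 2050 nM, and compound 2 `N=C(N)c1ccc(-c2ccc(-c3ccc(Cl)cc3)s2)cc1F` gives 726 nM. Compound 2 thus stands with the lowest number of the two; its nearest neighbour is compound 1, whose number is higher by an amount that lies beyond the usual scatter. Within the data shown here, the two compounds differ in more than one place, so no single step is drawn between them, and their two values say only that compound 2 is the stronger inhibitor of growth of the pair.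

The next compound, compound 3 `COc1ccc(-c2ccc(-c3ccc(C(=N)N)c(F)c3)s2)cc1`, has not yet been measured in this assay. It differs from compound 2 in one place: methoxy in place of chloro on an aromatic carbon. Among the measured compounds shown here, no measured pair shows this change, so its effect is unknown from the data. Compound 3 is expected to lie close to compound 2, with a small step of a 1.4-fold higher number from compound 2 to compound 3 (0.14 log units; within the scatter) toward a higher number, likely within the scatter. Compound 3 is therefore estimated at 1000 nM, with a range from 350 nM to 3000 nM.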

Compound 3, concentration for 50% growth inhibition: 4820 nM
Compound 3: the middle estimate sits 4.8-fold (0.68 log units) below what was measured; the whole stated range lies below it.
By their numbers in this assay, from the lowest: compound 2; then compound 1; then compound 3.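

Among these compounds, the change from chloro to methoxy is the first single change in these compounds that can be read: in this assay, at this place on an aromatic carbon, para to a large group, the swap gives a 6.6-fold higher number from compound 2 to compound 3 (0.82 log units; beyond the scatter) and so moves the number well beyond the scatter. The earlier pair differed in more than one place and could say nothing about one position alone, whereas this pair shows that growth inhibition responds to the group on this carbon, with chloro giving the stronger inhibitor of the two. No measurement at hand accounts for this difference, so its origin remains unexplained.

On these data alone, only chloro and methoxy can be compared at this carbon, so it remains open how other groups, such as a hydroxyl, an amine, a methyl or a longer chain such as ethoxy, would behave there. As far as these compounds go, it is also open whether the same swap would have a similar effect on a core lacking the fluoro shared by compound 2 and compound 3.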